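Chalcone series on a shared core: toward compound 4

This account rests on a few compounds, and the source may have more. Where it says the series, first, only, none or still open, it means among the compounds named here.

Measured compounds:
Compound 1 `CNC(=O)c1cc(Oc2ccc(C(=O)/C=C/c3ccc(C#N)cc3)cc2)ccn1` gives 9520 nM in a functional assay on MCF7 cells (Homo sapiens) for cytotoxicity, read by MTT assay, with a stated time of 72 h; on this read-out lower numbers stand for stronger inhibition and higher numbers for weaker inhibition.
Compound 2 `CNC(=O)c1cc(Oc2ccc(C(=O)/C=C/c3ccccc3)cc2)ccn1` gives 5960 nM in this assay.
Compound 3 `CNC(=O)c1cc(Oc2ccc(C(=O)/C=C/c3ccc(OC)cc3)cc2)ccn1` gives "not determined" (no result reported) in this assay, that is, no reported number.

The series keeps one core and varies the aryl group on the double-bonded chain carbon. Among the compounds with values here, the only step between measured compounds is a 1.6-fold lower number from compound 1 to compound 2 (0.20 log units; within the scatter), a change that leaves both numbers within the scatter of each other. Compound 3 stands without a value, so its position among the others cannot be stated; it can only be noted that compounds 1 and 2 sit close together.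

Compound 4 `CNC(=O)c1cc(Oc2ccc(C(=O)/C=C/c3ccc(Cl)c(Cl)c3)cc2)ccn1` differs from compound 3 as follows: 3,4-dichlorophenyl in place of 4-methoxyphenyl on a double-bonded chain carbon bound to a double-bonded chain carbon. Within the data shown here, no measured step covers a change of this kind, and the one step that exists, a 1.6-fold lower number from compound 1 to compound 2 (0.20 log units; within the scatter), concerns a different group and shows no movement beyond the scatter. Nothing in the shown data therefore supports expecting a shift beyond the scatter for compound 4 in this assay; the two measured values simply set the region where the series has so far landed.

Compound 4 is estimated to give about 5500 nM in this assay, expected to fall between 1500 nM and 20000 nM.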

Compound 4, half-maximal inhibitory concentration: 13200 nM
Compound 4: the middle estimate sits 2.4-fold (0.38 log units) below what was measured; the measured number falls inside the stated range.
By their numbers in this assay, from the lowest: compounds 2, 1 and 4 (each within the scatter of the next, the first and the last beyond it).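

At this place, on a double-bonded chain carbon bound to a double-bonded chain carbon, this assay now shows its first step beyond the scatter: a 2.2-fold higher number from compound 2 to compound 4 (0.35 log units; beyond the scatter), a modest move toward weaker inhibition on going from phenyl to 3,4-dichlorophenyl. The same entering group gives a 1.4-fold higher number from compound 1 to compound 4 (0.14 log units; within the scatter) when it replaces 4-cyanophenyl, so this change separates 3,4-dichlorophenyl from phenyl but not from 4-cyanophenyl, and the aryl group at this place has so far moved the number only modestly. The data shown offer no measurement that would explain this small shift.

The change from 4-methoxyphenyl to 3,4-dichlorophenyl itself cannot be read, since compound 3 has no number to compare with. Still open, as far as these compounds go, is how 4-chlorophenyl, or a phenyl ring carrying an amine or a carboxylic acid, would stand at this place against phenyl and 3,4-dichlorophenyl, and whether any such group would take the series clearly outside the range seen so far.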